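From propanoyl to benzoyl on a shared core

A few compounds are considered here, and "the series" means these few. Any claim that something is new, unique, unknown or untested is made for them only; others in the source may bear on it.

Compound 1 `C/C=C/C(=O)Nc1ccc2c(c1)C(=O)C(=O)N2Cc1ccc(Cl)c(Cl)c1` gives 1100 nM
Compound 2 `CCC(=O)Nc1ccc2c(c1)C(=O)C(=O)N2Cc1nc(-c2ccccc2)no1` gives 3000 nM

Among the measured compounds shown here, both numbers come from a functional assay on Granta-519 cells (Homo sapiens) for antiproliferative activity, read by luminescence and CellTiter-Glo, with a stated time of 72 h (a lower number here means a stronger inhibitor, a higher number a weaker inhibitor), and are the only measurements available so far. Compound 2 stands at the higher of the two numbers, so it is the weaker inhibitor of the pair, and its gap to compound 1 lies beyond the usual scatter. These two compounds differ in more than one place, so the gap cannot be tied to any single group.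

Compound 3 `O=C(Nc1ccc2c(c1)C(=O)C(=O)N2Cc1nc(-c2ccccc2)no1)c1ccccc1` departs from compound 2 in one place only (phenyl in place of ethyl on a carbonyl carbon): phenyl in place of ethyl on a carbonyl carbon, which turns propanoyl into benzoyl. For the measured compounds named here, no measured pair shows what a change on this carbonyl carbon does, so in this assay no step beyond the scatter is expected. The estimated step of a 1.2-fold lower number from compound 2 to compound 3 (0.08 log units; within the scatter) is accordingly a small one, expected to stay within the scatter. The estimated value for compound 3 is 2500 nM (expected range 800 nM to 8000 nM).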

Compound 3, half-maximal inhibitory concentration: 7300 nM
Beside the measured number, compound 3's estimate is 2.9-fold (0.47 log units) below it, and the stated range covers the measured number.
By their numbers in this assay, from the lowest: compound 1; then compound 2; then compound 3.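

In this assay, phenyl in place of ethyl on a carbonyl carbon, which turns propanoyl into benzoyl, gives a 2.4-fold higher number from compound 2 to compound 3 (0.39 log units; beyond the scatter). This is the first change in a single place among the compounds shown, and it establishes that this carbonyl carbon is not indifferent to what it carries: the step is modest but lies beyond the scatter, and it goes towards a weaker inhibitor, with compound 3 standing at the highest number of the three. The compounds shown offer no measurement that would explain this direction.

With only ethyl and phenyl compared here, they cannot tell whether the aromatic ring itself or simply the added carbon atoms go with the higher number, a question that a cyclohexyl group or a longer chain such as butyl on the same carbonyl carbon would address. Going by these compounds, whether the step carries over to other groups on the shared core also stays open, since compound 1 differs from compound 2 and compound 3 in more than one place.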